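Trimming the Acyl Chain on a Piperazine Triazine Core

The compounds below may be only part of what the source reports. "The series", "measured", "known", "first", "only" and "open" are said of these compounds alone.

Measured compounds:
compound 1, `c1nnc2nnc(N3CCCC3)nn12`: 4290 nM
compound 2, `CCCCCC(=O)N1CCN(c2nnc3nncn3n2)CC1`: 2960 nM
compound 3, `CCCCNc1nnc2nncn2n1`: 8640 nM

Of the compounds shown here, three sharing one core have been tested in a functional assay on BeWo cells (Homo sapiens) for inhibition, read by MTT assay, with a stated time of 72 h; on this read-out higher numbers stand for weaker inhibition and lower numbers for stronger inhibition. Compound 2 gives the lowest number of the three, yet its gap to compound 1 lies within the scatter, so no order between those two can be read; only compound 3 stands clearly apart with a higher number.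

Compound 4, `CC(=O)N1CCN(c2nnc3nncn3n2)CC1`, keeps the piperazine and the carbonyl of compound 2 and differs in one place: hydrogen in place of butyl on a saturated chain carbon bound to a carbonyl carbon.

For the measured compounds named here, no measured pair shows what such a shortening does here, so nothing beyond the scatter is expected, in either direction. The step from compound 2 is estimated as a 1.2-fold higher number from compound 2 to compound 4 (0.07 log units; within the scatter). For compound 4 the estimate in this assay is 3500 nM, with a range from 1500 nM to 8000 nM.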

Compound 4, half-maximal inhibitory concentration: 13100 nM
For compound 4 the middle estimate is 3.7-fold (0.57 log units) below the measured one; the measured number lies above the stated range.
By their numbers in this assay, from the lowest: compounds 2, 1, 3 and 4 (each within the scatter of the next, the first and the last beyond it).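

In this assay the change of hydrogen in place of butyl on a saturated chain carbon bound to a carbonyl carbon gives a 4.4-fold higher number from compound 2 to compound 4 (0.65 log units; beyond the scatter) and lies beyond the scatter. For the compounds shown here, this is the first sign that this position responds at all: pentylcarbonyl on the piperazine gives a lower number than acetyl. Nothing available accounts for this step.

Going by these compounds, whether an ethyl or propyl chain would keep the lower number remains open. So does the effect of a longer chain, such as octyl, or of an amine or carboxylic acid at the chain end.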